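The source may hold more compounds than are shown below. What is called first, only, known or untested is meant among the compounds shown, and "the series" means these compounds.

Measured so far in an ADME assay (Rattus norvegicus, strain Wistar Han) for pharmacokinetics; on this read-out lower numbers stand for narrower distribution and higher numbers for wider distribution into tissues:
- compound 1 `CCn1c(-c2cnc(C)nc2)nc2c(N[C@H]3CCN(C(=O)C4CC(F)(F)C4)C3)ncnc21`: 0.9 L/kg
- compound 2 `CCC(=O)N1CC[C@H](Oc2ncnc3c2nc(-c2cnc(C)nc2)n3CC)C1`: 1.2 L/kg
- compound 3 `CCn1c(-c2ccc(C(F)(F)F)nc2)nc2c(O[C@H]3CCN(C(=O)C4CC4)C3)ncnc21`: 0.7 L/kg

Compound 1 stands second highest of these three numbers, yet its gaps to compound 3 and to compound 2 both fall within the scatter, so the three values read as one level.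

Compound 4 `CCC(=O)N1CC[C@H](Nc2ncnc3c2nc(-c2cnc(C)nc2)n3CC)C1` is not yet measured. It differs from compound 1 in one place:
ethyl in place of 3,3-difluorocyclobutyl on a carbonyl carbon

Going by the values given here, no measured pair here isolates this exact change. Compound 2, which carries the propanoyl group on the shared core with a different linker, gives 1.2 L/kg, close to compound 1. The step from compound 1 to compound 4 is therefore expected to be a 1.1-fold higher number from compound 1 to compound 4 (0.05 log units; within the scatter), no more than the scatter and of no settled direction. Compound 4 is estimated at 1 L/kg, with a range of 0.6 L/kg to 1.7 L/kg.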

Compound 4, volume of distribution: 1 L/kg
For compound 4 middle estimate and measured number coincide at the digits printed; measured number inside the range.
By their numbers in this assay, from the lowest: compounds 3, 1, 4 and 2 (each within the scatter of the next).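

In this assay this pair gives the first direct read of this position, showing a 1.1-fold higher number from compound 1 to compound 4 (0.05 log units; within the scatter) with ethyl in place of 3,3-difluorocyclobutyl on a carbonyl carbon. The four-membered ring and its two fluorines can therefore be exchanged for the smaller open chain here with no step beyond the scatter. Nothing available explains this result. Still open, from the compounds shown here alone, is whether an amine, a carboxylic acid or a longer chain on this carbonyl carbon would give a step beyond the scatter.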